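A few compounds are considered here, and "the series" means these few. Any claim that something is new, unique, unknown or untested is made for them only; others in the source may bear on it.

Measured so far:
- compound 1 `COc1ccc(-n2cnc3cnc(Nc4cccc(NS(C)(=O)=O)c4)cc32)cc1OC` - 6900 nM
- compound 2 `COc1ccc(-n2cnc3cnc(-c4cccc(NC(C)=O)c4)cc32)cc1OC` - > 30000 nM (a limit)
- compound 3 `COc1ccc(-n2cnc3cnc(-c4ccccc4C)cc32)cc1OC` - 69 nM

All three values come from a functional assay on HL-60 cells (Homo sapiens) for activation, read by flow cytometry, with a stated time of 4 days (a lower number here means that less compound is needed, a higher number that more compound is needed for the effect), and are read as half-maximal effective concentrations. Among the measured compounds shown here, compound 3 gives the lowest number so far, 69 nM, and the gap to compound 1 at 6900 nM lies beyond the scatter. For compound 2, > 30000 nM is a limit of the assay and not a number. This is the only such result in hand, (the limit of > 30000 nM in this assay, at which 1 of the 3 values shown sits), so one of the three compounds gives no exact value for comparison.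

The next compound is compound 4 `COc1ccc(-n2cnc3cnc(-c4ccccc4OC(F)(F)F)cc32)cc1OC`, with trifluoromethoxy in place of methyl on an aromatic carbon, ortho to a large group: trifluoromethoxy in place of methyl on an aromatic carbon. For the measured compounds named here, no measured pair shows this change, and compound 1 and compound 2 differ from compound 3 in more than one place, so neither gives a measure of it. The expectation therefore starts from compound 3 at 69 nM and allows only a modest step toward a higher number in this assay, possibly one that stays within the scatter. The expected step is a 1.7-fold higher number from compound 3 to compound 4 (0.24 log units; within the scatter) as a central figure. For compound 4 the estimated value is 120 nM, with an expected range from 30 nM to 500 nM in this estimate.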

Compound 4, half-maximal effective concentration: 2500 nM
The estimate for compound 4 lay 21-fold (1.32 log units) below the measured number, outside the stated range (above it).
By their numbers in this assay, from the lowest: compound 3; then compound 4; then compound 1. At a limit, above all of these: compound 2.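

In this assay the aromatic carbon ortho to a large group, which carries methyl in compound 3, turns out not to tolerate every group: trifluoromethoxy in place of methyl gives a 36-fold higher number from compound 3 to compound 4 (1.56 log units; beyond the scatter) with the rest of the structure unchanged. Among the compounds shown here, this is the first measured step that changes one place only, and it is large. Compound 1 and compound 2 differ from compound 3 in more than one place and could not show that this single replacement alone moves the number beyond the scatter. Nothing in hand bears on the cause of this step, and the numbers record its size without explaining it.

With only methyl and trifluoromethoxy compared at this carbon, the series does not tell how methoxy, chlorine or an amine would read there in this assay or whether any of them would stay close to compound 3. On these data alone, it is also open whether the same replacement on another carbon of this ring would give a step of similar size.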